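Swapping the Five-Membered Ring on Compound 2

The source may hold more compounds than are shown below. What is called first, only, known or untested is meant among the compounds shown, and "the series" means these compounds.

Compound 1 `CC1=C(C(=O)OCC(C)C)C(c2ccoc2)NC(=O)N1`: 16%
Compound 2 `CC1=C(C(=O)OCc2ccccc2)C(c2ccoc2)NC(=O)N1`: 1%

In an assay on membranes from HeLa cells for displacement of a labelled ligand from adenosine receptor A3 (Homo sapiens), read by scintillation counting, with a stated time of 180 min, tested at 1 uM (on this read-out lower numbers stand for less inhibition and higher numbers for more inhibition at the one concentration tested (going by the name of the read-out)), compound 1 gives 16%, while compound 2 gives 1%. Within the data shown here, the one measured step, a number 15 percentage points lower from compound 1 to compound 2 (beyond the scatter), came with phenyl in place of isopropyl on a saturated chain carbon bound to an oxygen next to a carbonyl group. Among the measured compounds shown here, compound 2 therefore stands lowest of the two numbers, with compound 1 the only neighbour, and that neighbour is higher by a step beyond the scatter.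

Compound 3 `CC1=C(C(=O)OCc2ccccc2)C(c2cccs2)NC(=O)N1` keeps the ester of compound 2 and differs only in thiophen-2-yl in place of furan-3-yl on a saturated ring carbon. For the measured compounds named here, no measured step touches this position, so the change from compound 1 to compound 2 gives no direct guide; the account can only say that compound 2 starts from a very low number. Compound 3 is expected to show no step beyond the scatter, a number 5 percentage points higher from compound 2 to compound 3 (within the scatter). Compound 3 is estimated at 6%, with a range from -5% to 22%.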

Compound 3, a percentage reported as inhibition, at one concentration (the size of the read-out at that concentration, not a potency): 8%
Estimate against measurement, compound 3: 2 percentage points below; measured number inside the range.
By their numbers in this assay, from the lowest: compounds 2, 3 and 1 (each within the scatter of the next, the first and the last beyond it).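

Thiophen-2-yl in place of furan-3-yl on a saturated ring carbon gives the first reading at this position: a number 7 percentage points higher from compound 2 to compound 3 (within the scatter). The earlier compounds shown here showed a step beyond the scatter only at the ester, whereas here, with the ester of compound 2 held fixed, exchanging one five-membered aromatic ring with 1 hetero atom for another, sulfur for oxygen, leaves the two numbers within the scatter of each other. Nothing available explains this result or gives any measured property of either ring.

The compounds shown leave open whether the same exchange would read alike alongside the ester of compound 1. They also leave open how this ring carbon would respond to a group of a different kind, such as an amine or a carboxylic acid, in place of the five-membered ring.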